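A Methoxy for a Methyl on a Shared Core

The source may report more compounds than this note shows. Statements on the series, on what has been measured and on what is new or still open speak of the compounds shown alone.

Compound 1 `Cc1ncnc2c1c(I)cn2[C@@H]1O[C@H](CO)[C@@H](O)[C@H]1O`: 3460 nM
Compound 2 `Cc1ncnc2c1c(-c1cc3ccccc3o1)cn2[C@@H]1O[C@H](CO)[C@@H](O)[C@H]1O`: > 20000 nM
Compound 3 `Cc1ncnc2c1c(-c1ccoc1)cn2[C@@H]1O[C@H](CO)[C@@H](O)[C@H]1O`: 5320 nM

In a functional assay on HepG2 cells (Homo sapiens) for antiproliferative activity, read by XTT assay, with a stated time of 72 h (a lower number here means a stronger inhibitor, a higher number a weaker inhibitor), compound 1 gives 3460 nM. Compound 3 gives 5320 nM. For compound 2 the assay reports only a limit, > 20000 nM, and not a number. Compound 1 therefore gives the lower of the two numbers, with compound 3 sitting within the scatter of it, as a 1.5-fold higher number from compound 1 to compound 3 (0.19 log units; within the scatter) shows. The two steps that do go beyond the scatter, an at least 5.7-fold higher number from compound 1 to compound 2 (0.76 log units; beyond the scatter) and an at least 3.7-fold lower number from compound 2 to compound 3 (0.57 log units; beyond the scatter), concern the iodo position and the groups that replace it, where the benzofuran-bearing compound 2 sits at the assay limit (the limit of > 20000 nM in this assay, at which 1 of the 3 values shown sits).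

Compound 4 `COc1ncnc2c1c(I)cn2[C@@H]1O[C@H](CO)[C@@H](O)[C@H]1O` differs from compound 1 at a different place altogether:

methoxy in place of methyl on an aromatic carbon

Within the data shown here, none of the measured steps alters this position, so there is no measured step that bears directly on the change; the iodo-position steps say nothing about it. The expectation for compound 4 is therefore a step of a 1.0-fold higher number from compound 1 to compound 4 (0.00 log units; within the scatter), that is, no change beyond the scatter. Compound 4 is estimated at 3500 nM, within 1500 nM to 9000 nM.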

Compound 4, half-maximal inhibitory concentration: > 20000 nM
Compound 4 ended at the assay's limit; the forecaster's own chance of this, stated with the estimate: 5%; middle value at least 5.7-fold (0.75 log units) away from the limit.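

In this assay, among these compounds, methoxy in place of methyl gives an at least 5.7-fold higher number from compound 1 to compound 4 (0.76 log units; beyond the scatter), so this position, which none of the earlier steps touched, can move the result beyond the scatter with a single small change. Among the compounds shown here, until now, the only steps beyond the scatter concerned the iodo position and the groups replacing it; compound 4 shows a comparable loss at a second place on the shared core. Compound 4 is reported only as a limit, so its step has a minimum size and no exact one: the limit of > 20000 nM in this assay, at which 2 of the 4 values shown sit.

The compounds shown leave open whether the loss follows the entering oxygen or the larger group, and whether an amine, a chlorine or an ethyl here would retain the activity of compound 1. They also do not show how methoxy behaves alongside furan-3-yl in place of iodo.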